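A few compounds are considered here, and "the series" means these few. Any claim that something is new, unique, unknown or untested is made for them only; others in the source may bear on it.

Working notes on the series. Among the measured compounds shown here, compound 1 `CN1C[C@H](C(=O)Nc2ccc(C#N)cc2)[C@@H](c2ccc(/C=C/C(=O)Nc3ccccc3N)cc2)C1` gives 35 mL/min/kg in an in vitro ADME assay on microsomes from liver (Mus musculus) for pharmacokinetics, read by LC-MS, with a stated time of 10 min, tested at 1 uM (on this read-out higher numbers stand for fast clearance and lower numbers for slow clearance), the lowest of the two numbers so far; its nearest neighbour is compound 2 `CN1C[C@H](C(=O)Nc2cccc(F)c2)[C@@H](c2ccc(/C=C/C(=O)Nc3ccccc3N)cc2)C1` with 56 mL/min/kg, and that step is a 1.6-fold higher number from compound 1 to compound 2 (0.20 log units; within the scatter). The unmeasured compound 3 `CN1C[C@H](C(=O)Nc2ccc(Cl)c(Cl)c2)[C@@H](c2ccc(/C=C/C(=O)Nc3ccccc3N)cc2)C1` differs from compound 1 only at the amide-type nitrogen: 3,4-dichlorophenyl in place of 4-cyanophenyl on an amide-type nitrogen. For the measured compounds named here, the sole measured step at this position, from compound 1 to compound 2, stayed within the scatter, and no step to a dichlorophenyl group exists here. A step of a 1.6-fold higher number from compound 1 to compound 3 (0.20 log units; within the scatter) is therefore expected, with compound 3 estimated at 55 mL/min/kg, range 30 mL/min/kg to 100 mL/min/kg.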

Compound 3, clearance: 36 mL/min/kg
Estimate against measurement, compound 3: 1.5-fold (0.18 log units) above, and the stated range covers the measured number.
By their numbers in this assay, from the lowest: compounds 1, 3 and 2 (each within the scatter of the next).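

In this assay, the 3,4-dichlorophenyl group stays close to both earlier aryl groups on the amide-type nitrogen, with a 1.0-fold higher number from compound 1 to compound 3 (0.01 log units; within the scatter) and a 1.6-fold lower number from compound 2 to compound 3 (0.19 log units; within the scatter) as the two steps. The position has now taken a second change of aryl group, and replacing 4-cyanophenyl with a group without the nitrile or its hydrogen-bond acceptor still gives no step beyond the scatter. No supporting data bear on why these groups read alike.

As far as these compounds go, whether an aliphatic amine, a carboxylic acid or a cyclohexyl group at this position would give a step beyond the scatter remains open. Changes to the shared core also remain open.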